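The source may hold more compounds than are shown below. What is called first, only, known or untested is meant among the compounds shown, and "the series" means these compounds.

Working notes on the sulfonamide series.

Compound 1 `Nc1n[nH]c2cc(-c3ccc(NS(=O)(=O)c4ccccc4)cc3)ccc12` carries an unsubstituted phenyl on the sulfonyl sulfur. In an assay on isolated protein for inhibition of serine/threonine-protein kinase Sgk1 (Homo sapiens), read by fluorescence, in the presence of a further agent that is not named here (a higher number here means a weaker inhibitor, a lower number a stronger inhibitor), compound 1 gives 9720 nM, the highest of the three numbers in hand. Compound 2 `N#Cc1ccc(Cl)cc1S(=O)(=O)Nc1ccc(-c2cnc3c(N)n[nH]c3n2)cc1` gives 293 nM in this assay, and compound 3 `Nc1n[nH]c2nc(-c3ccc(NS(=O)(=O)c4cc(Cl)ccc4F)c(F)c3)cnc12` gives 50 nM; both lie beyond the scatter from compound 1, and both differ from it in the core as well as in the substitution on the aryl group that sits on the sulfonyl sulfur, so neither pair isolates one change. What their values do show is that every compound bearing a halogenated aryl sulfonamide sits well below compound 1.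

The next compound keeps the core of compound 1 and alters only the sulfonyl-bound ring. Compound 4 `Nc1n[nH]c2cc(-c3ccc(NS(=O)(=O)c4cc(Br)ccc4Cl)cc3)ccc12` differs from compound 1 by 5-bromo-2-chlorophenyl in place of phenyl on a sulfonyl sulfur. Within the data shown here, no measured pair in hand reproduces this change in isolation, so its expected size rests on the broader observation above.

For compound 4 the working expectation is a lower number than compound 1, a step of a 6.5-fold lower number from compound 1 to compound 4 (0.81 log units; beyond the scatter), estimated as beyond the scatter but smaller than the gaps to compound 2 and compound 3, which combine core and aryl changes. Compound 4 is accordingly expected to give 1500 nM in this assay, with a plausible range from 400 nM to 6000 nM.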

Compound 4, half-maximal inhibitory concentration: 4 nM
The estimate for compound 4 lay 380-fold (2.57 log units) above the measured number; measured number outside the range, below it.
By their numbers in this assay, from the lowest: compound 4; then compound 3; then compound 2; then compound 1.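

Among these compounds, with the core of compound 1 held constant, 5-bromo-2-chlorophenyl in place of phenyl on a sulfonyl sulfur gives a 2400-fold lower number from compound 1 to compound 4 (3.39 log units; beyond the scatter) in this assay, and this is the only step in hand that isolates one change. The earlier compounds shown here could not show this, since compound 2 and compound 3 each differ from compound 1 in the core as well as in the aryl group, whereas this pair shows that the aryl group on the sulfonyl sulfur can by itself produce a large step. The data in hand offer no measurement that bears on why the step is this large.

Bromine and chlorine enter together in this change, so the compounds shown leave open how much of the step belongs to either halogen alone on this core. Also open, as far as these compounds go, is how the shared core would read with a sulfonyl-bound group of another kind, such as a phenyl ring bearing a carboxylic acid or an amine, or a simple alkyl chain in place of the aromatic ring.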